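A few compounds are considered here, and "the series" means these few. Any claim that something is new, unique, unknown or untested is made for them only; others in the source may bear on it.

Two measurements frame this account. In a functional assay for inhibition of sodium/hydrogen exchanger (Oryctolagus cuniculus) (on this read-out higher numbers stand for weaker inhibition and lower numbers for stronger inhibition), compound 1 `CCc1cc(C)c(C(=O)N=C(N)N)cc1S(C)(=O)=O` gives 4.8 nM. Compound 2 `Cc1cc(Sc2ccc(Cl)cc2)c(S(C)(=O)=O)cc1C(=O)N=C(N)N` in this assay gives 19 nM. Among the measured compounds shown here, compound 2 therefore stands at the higher of the two numbers, and the only measured step, a 4.0-fold higher number from compound 1 to compound 2 (0.60 log units; beyond the scatter), separates it from compound 1.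

Compound 3 `Cc1cc(-n2ccnc2)c(S(C)(=O)=O)cc1C(=O)N=C(N)N` is the next point. The change is 1H-imidazol-1-yl in place of (4-chlorophenyl)sulfanyl on an aromatic carbon. That single step bears on it only in part: it shows that exchanging the group at this position for (4-chlorophenyl)sulfanyl moved the number by a modest amount, but nothing measured tells how 1H-imidazol-1-yl behaves there. The step from compound 1 to compound 2 gives the scale of what one substituent swap at this carbon has done. With a smaller five-membered ring entering and the group that raised the number leaving, a number between the two measured values seems most plausible. For compound 3 in this assay the estimate is 10 nM, within a range of 3 nM to 35 nM, which would mean an expected step of a 1.9-fold lower number from compound 2 to compound 3 (0.28 log units; within the scatter).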

Compound 3, half-maximal inhibitory concentration: 23 nM
Estimate against measurement, compound 3: 2.3-fold (0.36 log units) below; the measured number falls inside the stated range.
By their numbers in this assay, from the lowest: compound 1; then compounds 2 and 3 (each within the scatter of the next).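

In this assay, putting 1H-imidazol-1-yl in place of (4-chlorophenyl)sulfanyl gives a 1.2-fold higher number from compound 2 to compound 3 (0.08 log units; within the scatter), so on this read-out the two groups cannot be told apart, although they differ in ring size, heavy atoms and hetero atoms. Measured against ethyl, 1H-imidazol-1-yl gives a 4.8-fold higher number from compound 1 to compound 3 (0.68 log units; beyond the scatter), and (4-chlorophenyl)sulfanyl gives a 4.0-fold higher number from compound 1 to compound 2 (0.60 log units; beyond the scatter), so among these three compounds both aromatic groups on this carbon, ortho to the methylsulfonyl group, stand beyond the scatter from the ethyl compound, and none of the three goes against that. Nothing available accounts for why two such different groups give numbers within the scatter of each other.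

The compounds shown leave open whether a small group such as methoxy, an amine or a chlorine atom on this carbon would give a number nearer compound 1 or nearer compounds 2 and 3. They also leave open whether a longer alkyl chain, or a phenyl ring attached directly without the sulfur, would keep the number of the ethyl compound or join the two aromatic groups.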